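A few compounds are considered here, and "the series" means these few. Any claim that something is new, unique, unknown or untested is made for them only; others in the source may bear on it.

Measured in an in vitro ADME assay on microsomes from liver (Homo sapiens) for pharmacokinetics, read by LC-MS, with a stated time of 10 min, tested at 1 uM; a higher number here means faster removal of the compound, a lower number slower removal:
- compound 1 `CN1C[C@H](C(=O)Nc2cccc(Cl)c2)[C@@H](c2ccc(/C=C/C(=O)Nc3ccccc3N)cc2)C1`: 7 mL/min/kg
- compound 2 `Cc1ccc(NC(=O)[C@H]2CN(C)C[C@@H]2c2ccc(/C=C/C(=O)Nc3ccccc3N)cc2)cn1`: 8 mL/min/kg

Compound 2, at 8 mL/min/kg, stands level with compound 1 within the scatter. The next compound, compound 3 `CN1C[C@H](C(=O)NC2CCCC2)[C@@H](c2ccc(/C=C/C(=O)Nc3ccccc3N)cc2)C1`, changes the same place: cyclopentyl in place of 6-methylpyridin-3-yl on an amide-type nitrogen. Cyclopentyl thus replaces 6-methylpyridin-3-yl on an amide-type nitrogen. Going by the values given here, only one measured step bears on this, a 1.1-fold higher number from compound 1 to compound 2 (0.06 log units; within the scatter), which exchanged 3-chlorophenyl for 6-methylpyridin-3-yl on that nitrogen. It stayed within the scatter, but both of those groups are six-membered aromatic rings, whereas cyclopentyl is a five-membered non-aromatic ring of carbon only. Among the compounds with values here, no measured compound carries such a ring, so the guide is weak and the direction is uncertain. In this assay, the expected change is small, with no shift beyond the scatter estimated: a 1.1-fold higher number from compound 2 to compound 3 (0.05 log units; within the scatter). Compound 3 is expected at 9 mL/min/kg, within an estimated range of 5 mL/min/kg to 17 mL/min/kg.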

Compound 3, clearance: 9 mL/min/kg
Compound 3: middle estimate and measured number agree at the digits printed; measured number inside the range.
By their numbers in this assay, from the lowest: compounds 1, 2 and 3 (each within the scatter of the next).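

Across the three groups on the amide-type nitrogen in this assay, the aromatic ring could give way to a non-aromatic one without the number leaving the scatter. The step is a 1.1-fold higher number from compound 2 to compound 3 (0.05 log units; within the scatter), and measured against the chlorinated ring it is a 1.3-fold higher number from compound 1 to compound 3 (0.11 log units; within the scatter), so cyclopentyl, a five-membered ring of carbon only, sits level with both six-membered aromatic rings. Nothing available here explains why the type of ring makes so little difference in these compounds.

Still open, as far as these compounds go, is whether a group that carries an amine or a carboxylic acid on this nitrogen, or an open chain such as n-butyl, would stay level with these three. The compounds shown also leave open how the number responds to a change anywhere else on the shared core.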